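Working notes: amide-side replacement in the aryloxyquinoline series

This account rests on a few compounds, and the source may have more. Where it says the series, first, only, none or still open, it means among the compounds named here.

Measured in a functional assay on HT-29 cells (Homo sapiens) for cytotoxicity, read by MTT assay, with a stated time of 72 h; a higher number here means a weaker inhibitor, a lower number a stronger inhibitor:
compound 1 `COc1cc2c(Oc3ccc(NC(=O)c4cn(-c5cc(C)ccc5C)cn4)cc3F)ccnc2cc1OCCCN1CCN(C)CC1` gives 470 nM
compound 2 `COc1cc2c(Oc3ccc(NC(=O)c4cn(-c5ccc(Cl)cc5)cn4)cc3F)ccnc2cc1OCCCN1CCN(C)CC1` gives 1350 nM

Compound 2 holds the higher of the two numbers; its nearest neighbour is compound 1, separated by the step of a 2.9-fold higher number from compound 1 to compound 2 (0.46 log units; beyond the scatter), a change confined to the aryl group on the aromatic nitrogen.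

Compound 3 `COc1cc2c(Oc3ccc(NC(=O)/C=C/S(=O)(=O)c4ccccc4F)cc3F)ccnc2cc1OCCCN1CCN(C)CC1` is not yet measured. Relative to compound 2 it carries 2-((2-fluorophenyl)sulfonyl)ethenyl in place of 1-(4-chlorophenyl)-1H-imidazol-4-yl on a carbonyl carbon. For the measured compounds named here, the only measured step, a 2.9-fold higher number from compound 1 to compound 2 (0.46 log units; beyond the scatter), alters the aryl substituent on the imidazole while keeping the imidazolyl amide itself; it does not speak to removal of that heteroaryl in favour of an open-chain sulfonyl-ethenyl group. Going by the values given here, no measured pair therefore bears directly on the change from compound 2 to compound 3, and the expectation rests only on the fact that the shared core and the amide linkage are retained.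

For compound 3 the estimate in this assay is 1000 nM, with a range of 200 nM to 5000 nM, which corresponds to an expected step of a 1.4-fold lower number from compound 2 to compound 3 (0.13 log units; within the scatter), treated as uncertain in direction.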

Compound 3, half-maximal inhibitory concentration: 150 nM
Beside the measured number, compound 3's estimate is 6.7-fold (0.82 log units) above it, outside the stated range (below it).
By their numbers in this assay, from the lowest: compound 3; then compound 1; then compound 2.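

Until now this position had been varied only through the aryl group on the aromatic nitrogen, with the imidazolyl amide kept. Compound 3 shows that the whole 1-(4-chlorophenyl)-1H-imidazol-4-yl can be exchanged on the carbonyl carbon for the open-chain 2-((2-fluorophenyl)sulfonyl)ethenyl without loss in this assay, giving a 9.0-fold lower number from compound 2 to compound 3 (0.95 log units; beyond the scatter). The two groups have the same heavy-atom, donor and acceptor counts, so these counts do not separate them, and no supporting data are available to explain the step.

The exchange changes the sulfonyl, the ethenyl and the aryl substituent all at once, so the compounds shown do not assign the step to any one of them. A saturated ethyl linker in place of the ethenyl, a sulfonamide in place of the sulfonyl, or an unsubstituted phenyl or 4-chlorophenyl in place of the 2-fluorophenyl would each isolate one of these parts.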